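The source may hold more compounds than are shown below. What is called first, only, known or untested is meant among the compounds shown, and "the series" means these compounds.

Measured so far:
compound 1 `ClCc1ccc(Cn2cnc3c(Cl)ncnc32)cc1` with 4570 nM
compound 2 `ClCc1ccccc1Cn1cnc2c(Cl)nc(Cl)nc21` with 1510 nM

In a functional assay on UO-31 cells (Homo sapiens) for cytotoxicity, read by sulforhodamine B assay, with a stated time of 48 h (on this read-out lower numbers stand for stronger inhibition of growth and higher numbers for weaker inhibition of growth), compound 2 gives the lowest of the two numbers, and compound 1 gives the higher one. Compound 3 `ClCc1ccccc1Cn1cnc2c(Cl)ncnc21` has not yet been measured in this assay. It differs from compound 2 in one place: hydrogen in place of chloro on an aromatic carbon, on the aromatic carbon that sits between two ring nitrogen atoms. Going by the values given here, no measured pair shows this change, so the expectation rests on little. A modest loss of growth inhibition is expected, a 2.0-fold higher number from compound 2 to compound 3 (0.30 log units; within the scatter), and compound 3 is therefore estimated at 3000 nM, between 1000 nM and 9000 nM.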

Compound 3, concentration for total growth inhibition: 10500 nM
Beside the measured number, compound 3's estimate is 3.5-fold (0.54 log units) below it; measured number outside the range, above it.
By their numbers in this assay, from the lowest: compound 2; then compound 1; then compound 3.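

Putting hydrogen in place of the chloro group on the aromatic carbon between two ring nitrogen atoms gives a 7.0-fold higher number from compound 2 to compound 3 (0.84 log units; beyond the scatter), a step beyond the usual scatter. Going by these compounds alone, this is the first pair that differs only at this position, and it shows that the chloro group there goes with stronger inhibition of growth. No available evidence accounts for this step. The compounds shown leave open how an amine, a methoxy group or a longer chain on this carbon would compare with chloro and hydrogen.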